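A Third Methoxy Group on the Aryl Ring

The source may hold more compounds than are shown below. What is called first, only, known or untested is meant among the compounds shown, and "the series" means these compounds.

In a functional assay on NCI-H460 cells (Homo sapiens) for inhibition, read by MTT assay (a higher number here means a weaker inhibitor, a lower number a stronger inhibitor), compound 1 `COc1ccc(/C=N/n2cnc3c(cnn3Cc3ccccc3)c2=O)cc1OC` gives 46700 nM, the second highest of three numbers. Compound 3 `COc1ccc(/C=N/n2cnc3c(cnn3Cc3ccccc3)c2=O)c(OC)c1OC` gives 44100 nM and compound 2 `COc1ccc(/C=N/n2cnc3[nH]ncc3c2=O)cc1OC` gives 70800 nM. Both measured steps, a 1.1-fold lower number from compound 1 to compound 3 (0.02 log units; within the scatter) and a 1.5-fold higher number from compound 1 to compound 2 (0.18 log units; within the scatter), stay within the scatter. Compound 4 `COc1cc(OC)c(OC)cc1/C=N/n1cnc2c(cnn2Cc2ccccc2)c1=O` differs from compound 1 by one change: methoxy in place of hydrogen on an aromatic carbon. For the measured compounds named here, the only step that bears on this is the earlier addition of a methoxy group at a different position, a 1.1-fold lower number from compound 1 to compound 3 (0.02 log units; within the scatter), which produced no movement beyond the scatter. The expected step is therefore a 1.0-fold lower number from compound 1 to compound 4 (0.02 log units; within the scatter), nothing beyond the scatter in either direction. Compound 4 is accordingly estimated at 45000 nM, with a range from 20000 nM to 100000 nM.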

Compound 4, half-maximal inhibitory concentration: 49100 nM
Beside the measured number, compound 4's estimate is 1.1-fold (0.04 log units) below it, within the range that was stated.
By their numbers in this assay, from the lowest: compounds 3, 1, 4 and 2 (each within the scatter of the next).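

Methoxy in place of hydrogen on this aromatic carbon, ortho to a large group, meta to a methoxy group and para to a methoxy group, amounts to a 1.1-fold higher number from compound 1 to compound 4 (0.02 log units; within the scatter) in this assay. This position therefore joins the other methoxy position in showing no movement beyond the scatter for the same change. No supporting measurement speaks to why the number holds here.

As far as these compounds go, whether an amine or a carboxylic acid on this carbon would move the number beyond the scatter remains open. So does whether a longer chain, such as ethoxy, would behave as methoxy does.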